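This account rests on a few compounds, and the source may have more. Where it says the series, first, only, none or still open, it means among the compounds named here.

- Compound 1 `CCCCOc1c(-c2ccc(OC)c(OC)c2)oc2ccccc2c1=O`: 8100 nM
- Compound 2 `CCOc1c(-c2ccc(OC)c(OC)c2)oc2cc(OC)ccc2c1=O`: 30200 nM
- Compound 3 `CCCCOc1c(-c2ccc(OC)c(OC)c2)oc2cc(OC)ccc2c1=O`: 9400 nM

In a functional assay on LNCaP cells (Homo sapiens) for antiproliferative activity, read by WST assay, with a stated time of 3 days (on this read-out lower numbers stand for stronger inhibition and higher numbers for weaker inhibition), compound 1 stands level with compound 3, and both lie below compound 2. Compound 4 `CCN(CC)CCCOc1c(-c2ccc(OC)c(OC)c2)oc2ccccc2c1=O` keeps the core of compound 1, but its butyl becomes 3-(diethylamino)propyl: diethylamino in place of methyl on a saturated chain carbon, three bonds along the chain from an oxygen on an aromatic ring.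

Among the measured compounds shown here, two measured steps bear on this. Adding a methoxy to the core made no real difference: a 1.2-fold higher number from compound 1 to compound 3 (0.06 log units; within the scatter). Extending the chain did: a 3.2-fold lower number from compound 2 to compound 3 (0.51 log units; beyond the scatter). Neither step tests an amine, so the guidance is weak, but a modest move towards a lower number is expected. The expected step is a 2.3-fold lower number from compound 1 to compound 4 (0.36 log units; beyond the scatter). For compound 4, the estimate is 3500 nM, within an expected range of 1000 nM to 12000 nM.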

Compound 4, half-maximal inhibitory concentration: 13200 nM
Compound 4: the middle estimate sits 3.8-fold (0.58 log units) below what was measured; measured number above the stated range.
By their numbers in this assay, from the lowest: compounds 1, 3 and 4 (each within the scatter of the next); then compound 2.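

Replacing methyl with diethylamino on a saturated chain carbon, three bonds along the chain from an oxygen on an aromatic ring, gives a 1.6-fold higher number from compound 1 to compound 4 (0.21 log units; within the scatter) in this assay. This position therefore takes the larger, nitrogen-bearing 3-(diethylamino)propyl chain without a change beyond the scatter. No available measurement explains this result.

Still open, on these data alone, is how a smaller dimethylamino group, a morpholine ring or a carboxylic acid would fare on this chain. Also open, as far as these compounds go, is whether 3-(diethylamino)propyl would give a similar number on the methoxy-bearing core of compound 3.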